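From 4-chlorophenyl to 4-fluorophenyl at one aromatic carbon

The compounds below may be only part of what the source reports. "The series", "measured", "known", "first", "only" and "open" are said of these compounds alone.

Three compounds sharing one core have been measured in a functional assay on A-431 cells (Homo sapiens) for inhibition, read by MTT assay, with a stated time of 72 h (a higher number here means a weaker inhibitor, a lower number a stronger inhibitor), so far:

- compound 1 `COc1ccc(-c2nnc(SCCCN3CCN(c4nc5ccccc5o4)CC3)o2)cc1` gives 52700 nM
- compound 2 `O=[N+]([O-])c1ccc(-c2nnc(SCCCN3CCN(c4nc5ccccc5o4)CC3)o2)cc1` gives 46900 nM
- compound 3 `Clc1ccc(-c2nnc(SCCCN3CCN(c4nc5ccccc5o4)CC3)o2)cc1` gives 89600 nM

Compound 3 cannot be separated from the other two compounds in this assay on these numbers. Its neighbours are a 1.7-fold higher number from compound 1 to compound 3 (0.23 log units; within the scatter) and a 1.9-fold higher number from compound 2 to compound 3 (0.28 log units; within the scatter) on the measured scale.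

Compound 4 `Fc1ccc(-c2nnc(SCCCN3CCN(c4nc5ccccc5o4)CC3)o2)cc1` is compound 3 with fluoro in place of chloro on an aromatic carbon, para to a large group. The change, 4-chlorophenyl to 4-fluorophenyl, counts as fluoro in place of chloro on an aromatic carbon in full. Among the measured compounds shown here, no fluoro compound has been measured yet, so the only guide is the other swaps at this same place. Besides the two steps above there is a 1.1-fold lower number from compound 1 to compound 2 (0.05 log units; within the scatter) in the same series. All three stay within the scatter across methoxy, nitro and chloro, so no step beyond the scatter is expected in this assay here. The expected step is a 1.4-fold lower number from compound 3 to compound 4 (0.14 log units; within the scatter) and no direction is firmly implied. Compound 4 is thus estimated at 65000 nM with 32000 nM and 120000 nM as the ends of its expected range.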

Compound 4, half-maximal inhibitory concentration: 136000 nM
Compound 4: the middle estimate sits 2.1-fold (0.32 log units) below what was measured; measured number outside the range, above it.
By their numbers in this assay, from the lowest: compounds 2, 1, 3 and 4 (each within the scatter of the next, the first and the last beyond it).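

In this assay fluoro in place of chloro at this position gives a 1.5-fold higher number from compound 3 to compound 4 (0.18 log units; within the scatter) and so leaves the two halogens unseparated. Among the compounds shown here, what is new is that a change at this position can now pass the scatter: a 2.9-fold higher number from compound 2 to compound 4 (0.46 log units; beyond the scatter) and a 2.6-fold higher number from compound 1 to compound 4 (0.41 log units; beyond the scatter) are the first steps to do so, though both are modest, while compound 3 remains within the scatter of the other three. Nothing available explains these differences.

The compounds shown leave open whether an amine, a carboxylic acid or a hydroxyl at this position would shift the number by more than these modest steps. They also leave open whether a longer chain in the linker would change the picture for the shared core.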